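Changing the ring-nitrogen aryl group in a thiophene series

A few compounds are considered here, and "the series" means these few. Any claim that something is new, unique, unknown or untested is made for them only; others in the source may bear on it.

Measured compounds:
Compound 1, `CC(C)N1CCN(Cc2csc(N)c2C(=O)c2ccc(Cl)cc2)CC1`: 0%
Compound 2, `Nc1scc(CN2CCN(c3cc(Cl)cc(Cl)c3)CC2)c1C(=O)c1ccc(Cl)cc1`: 1%
Compound 3, `Nc1scc(CN2CCN(c3ccc(Cl)c(C(F)(F)F)c3)CC2)c1C(=O)c1ccc(Cl)cc1`: 3%

All three share one core and differ only in the group on an amine nitrogen in a ring. In an assay on CHO cells for displacement of a labelled ligand from adenosine receptor A3 (Homo sapiens), read by scintillation counting, with a stated time of 120 min, tested at 10 uM (on this read-out higher numbers stand for more inhibition at the one concentration tested (going by the name of the read-out) and lower numbers for less inhibition), compound 1 gives 0%, compound 2 gives 1% and compound 3 gives 3%. Compound 3 sits at the top of these three numbers, yet every gap between them lies within the scatter: a number 1 percentage points higher from compound 1 to compound 2 (within the scatter), a number 3 percentage points higher from compound 1 to compound 3 (within the scatter) and a number 2 percentage points higher from compound 2 to compound 3 (within the scatter). In plain terms, none of the three shows any real inhibition in this assay.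

Compound 4, `Nc1scc(CN2CCN(c3cccc4ccccc34)CC2)c1C(=O)c1ccc(Cl)cc1`, has not yet been measured. It differs from compound 3 by naphthalen-1-yl in place of 4-chloro-3-(trifluoromethyl)phenyl on an amine nitrogen in a ring. Going by the values given here, every step so far that swaps the group on this ring nitrogen, whether from isopropyl to an aryl group or from one aryl group to another, has left the read-out flat. Nothing in these numbers suggests that a further aryl swap at the same place would move it beyond the scatter.

Compound 4 is therefore expected to give 3% in this assay, with a likely range from -8% to 15%. The expected step is no change at the digits printed from compound 3 to compound 4 (within the scatter), that is, no change beyond the scatter.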

Compound 4, a percentage reported as inhibition, at one concentration (the size of the read-out at that concentration, not a potency): 0%
Compound 4: the middle estimate sits 3 percentage points above what was measured; the range from low to high includes it.
By their numbers in this assay, from the lowest: compounds 1, 4, 2 and 3 (each within the scatter of the next).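

The swap to naphthalen-1-yl gives a number 3 percentage points lower from compound 3 to compound 4 (within the scatter) in this assay, and the same group gives a number 1 percentage points lower from compound 2 to compound 4 (within the scatter) and no change at the digits printed from compound 1 to compound 4 (within the scatter). This extends the flat picture to a new kind of group: naphthalen-1-yl has two six-membered aromatic rings and only carbon atoms, whereas the earlier aryl groups have a single ring carrying chlorine or fluorine. At this ring nitrogen, then, isopropyl, the two halogen-bearing phenyl groups and this larger, halogen-free aryl group cannot be told apart by this read-out, and no measured evidence here accounts for that.

From the compounds shown here alone, all four groups on this nitrogen are built only from carbon, hydrogen and halogens, so it remains open whether a carboxylic acid, a hydroxyl group or a longer chain ending in an amine would lift the number above the scatter. Going by these compounds, all four compounds also carry the same shared core, including its 4-chlorobenzoyl part, so it also remains open whether a change there would alter the picture.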